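This account rests on a few compounds, and the source may have more. Where it says the series, first, only, none or still open, it means among the compounds named here.

- compound 1 `CCc1ccc(SCc2ccc(C(=O)Nc3ccccc3N)cc2)cc1`: 30.8%
- compound 2 `Nc1ccccc1NC(=O)/C=C/c1ccc(CSc2cccc3ccccc23)cc1`: 20.6%

Of the compounds shown here, two have been measured in a functional assay on HeLa cells (Homo sapiens) for inhibition, read by CCK-8 assay, with a stated time of 72 h, tested at 2 uM; a higher number here means more inhibition of growth at the concentration tested, a lower number less inhibition of growth. Compound 1 stands highest of the two at 30.8%, while compound 2 gives 20.6%, a gap beyond the scatter. Compound 3 `Nc1ccccc1NC(=O)c1ccc(CSCCc2ccccc2)cc1` has not yet been measured. Compared with compound 1, it carries phenethyl in place of 4-ethylphenyl on a sulfur. The two compounds have the same atoms, joined differently. Among the compounds with values here, no measured pair of compounds differs in one place only, so the data show nothing directly about the size of such a change. The expectation is therefore cautious: a small downward move that does not go beyond the scatter. The estimated step is a number 4.8 percentage points lower from compound 1 to compound 3 (within the scatter). For compound 3 the expected value in this assay is 26%, within an estimated range of 11% to 42%.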

Compound 3, percent growth inhibition at one concentration: 27.7%
The estimate for compound 3 lay 1.7 percentage points below the measured number; measured number inside the range.
By their numbers in this assay, from the lowest: compounds 2, 3 and 1 (each within the scatter of the next, the first and the last beyond it).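

In this assay, within the data shown here, phenethyl in place of 4-ethylphenyl on a sulfur gives a number 3.1 percentage points lower from compound 1 to compound 3 (within the scatter), the first step in this set that isolates a single place. The two groups match in their count of eight carbon atoms and in carrying one six-membered aromatic ring, and this rearrangement of the same atoms, moving from a ring joined directly to the sulfur to one joined through a chain, does not separate compound 3 from compound 1 in this read-out. Nothing measured here offers an explanation for this result.

This single pair leaves open whether any other group on this sulfur would produce a step beyond the scatter. A longer chain, an amine or a carboxylic acid at this place remains untested among the compounds shown here.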